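Carbamoylphenyl exchanged for a dioxo-bearing heteroaromatic ring

The source may report more compounds than this note shows. Statements on the series, on what has been measured and on what is new or still open speak of the compounds shown alone.

Compound 1 `NC(=O)c1cccc(-c2cnc(C(=O)CCCCCCc3ccccc3)o2)c1` is the starting point of this step. In an assay on isolated protein for inhibition of liver carboxylesterase 1 (Homo sapiens) (a higher number here means a weaker inhibitor, a lower number a stronger inhibitor), compound 1 reaches only the limit of the assay, > 100000 nM, and no number is known for it. The two measured neighbours are compound 2 `COc1ccnc(-c2cnc(C(=O)CCCCCCc3ccccc3)o2)c1`, which in this assay gives 500 nM, and compound 3 `COc1ncc(-c2cnc(C(=O)CCCCCCc3ccccc3)o2)c(OC)n1`, which in this assay gives 3000 nM.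

Compound 4 `O=C(CCCCCCc1ccccc1)c1ncc(-c2cc(=O)[nH]c(=O)[nH]2)o1` has not yet been measured. Against compound 1 the change is a group of 8 heavy atoms (4 carbon, 2 nitrogen, 2 oxygen; one six-membered aromatic ring with 2 hetero atoms) in place of a group of 9 heavy atoms (7 carbon, 1 nitrogen, 1 oxygen; one six-membered aromatic ring of carbon only), on an aromatic carbon, placed next to the ring oxygen of the shared core and two ring bonds from the ring nitrogen.

For the measured compounds named here, one measured step touches the same position: an at least 200-fold lower number from compound 1 to compound 2 (2.30 log units; beyond the scatter). Its size is only a lower bound, since the value of compound 1 is a limit (the limit of > 100000 nM in this assay, at which 1 of the 3 values shown sits). It shows that a six-membered ring with hetero atoms in place of 3-carbamoylphenyl can bring the number down strongly; compound 3 shows that a ring with two hetero atoms also stays inside the measurable range. Going by the values given here, the entering group of compound 4 carries two donors and two acceptors, which no measured compound does, so the step is expected to be smaller and uncertain: compound 4 is estimated at 40000 nM, between 5000 nM and 150000 nM, which means an expected step of an at least 2.5-fold lower number from compound 1 to compound 4 (0.39 log units; beyond the scatter).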

Compound 4, half-maximal inhibitory concentration: 30000 nM
The estimate for compound 4 lay 1.3-fold (0.12 log units) above the measured number, and the stated range covers the measured number.
By their numbers in this assay, from the lowest: compound 2; then compound 3; then compound 4. At a limit, above all of these: compound 1.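

In this assay a ring with 2 hetero atoms that brings 2 hydrogen-bond donors and 2 hydrogen-bond acceptors to this position still gives an at least 3.3-fold lower number from compound 1 to compound 4 (0.52 log units; beyond the scatter) against 3-carbamoylphenyl, so the measurable range at this position extends to a group of this kind. Hetero atoms in a six-membered ring do not by themselves secure the level of compound 2, however: with 8 heavy atoms in both entering groups, the exchange of the 4-methoxypyridin-2-yl ring for the ring of compound 4 gives a 60-fold higher number from compound 2 to compound 4 (1.78 log units; beyond the scatter) and so separates two rings of equal size by a large margin. Compound 1 stands at a limit, so the step that starts from it gives only a lower bound on the gain: the limit of > 100000 nM in this assay, at which 1 of the 4 values shown sits.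

The compounds shown leave open whether the higher number of compound 4 goes with its two ring carbonyls or with its ring amide hydrogens, a question that a methyl group on each ring nitrogen would address. As far as these compounds go, how an amine or a carboxylic acid on the same ring would fare at this position also remains open.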